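Replacing Phenyl with Hydrogen on an Amide-Type Nitrogen

This account rests on a few compounds, and the source may have more. Where it says the series, first, only, none or still open, it means among the compounds named here.

Compound 1 `CCCNC(=O)C1CCc2cc(O)c(OC)cc2O1` gives 119000 nM
Compound 2 `COc1cc2c(cc1O)C(=O)CC(C(=O)Nc1ccccc1)O2` gives 293000 nM

In a functional assay (brain) for inhibition, with Rattus norvegicus as the target (on this read-out lower numbers stand for stronger inhibition and higher numbers for weaker inhibition), compound 2 has the higher of the two numbers at 293000 nM and so shows the weaker inhibition. Compound 1 lies below it by more than the usual scatter, although the two structures differ in more than one place. Compound 3 `COc1cc2c(cc1O)C(=O)CC(C(N)=O)O2` has not yet been measured. It carries hydrogen in place of phenyl on an amide-type nitrogen and otherwise matches compound 2. Among the compounds with values here, no measured pair shows this change, so only a modest move towards a lower number is expected, and it may stay within the scatter. The expected change is a 1.5-fold lower number from compound 2 to compound 3 (0.17 log units; within the scatter) in size. Compound 3 is estimated at 200000 nM in this assay with an expected range from 70000 nM to 600000 nM as its measurement is awaited.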

Compound 3, half-maximal inhibitory concentration: > 300000 nM
Compound 3 gave a limit, no number (the forecaster's own chance of this, stated with the estimate: 15%); middle value at least 1.5-fold (0.17 log units) away from the limit.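

For compound 3, the result in this assay is a limit of the assay and not a number: the limit of > 300000 nM in this assay, at which 1 of the 3 values shown sits. Hydrogen in place of phenyl on an amide-type nitrogen gives an at least 1.0-fold higher number from compound 2 to compound 3 (0.01 log units; that floor lies within the scatter), the first reading of a change at this one place, since compound 1 and compound 2 differ in more than one place. This step shows no sign of a lower number once the phenyl has gone, but its floor lies within the scatter, so it cannot tell whether inhibition truly weakens or stays level.

On these data alone, how far the true value of compound 3 lies past its limit remains open. Also open, as far as these compounds go, is what a methyl or a benzyl group on this amide-type nitrogen would give, and so whether anything between hydrogen and phenyl moves the number at all.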